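Pyrazolyl for ethyl: oral exposure in the series

The source may hold more compounds than are shown below. What is called first, only, known or untested is meant among the compounds shown, and "the series" means these compounds.

In an ADME assay on the whole organism (strain Han-Wistar) for pharmacokinetics, with Rattus norvegicus as the target, read by LC-MS, at a dose of 2 mg/kg by the oral route (on this read-out higher numbers stand for higher exposure at the dose given and lower numbers for lower exposure), compound 2 `CCc1ccc(Cl)c(C(=O)NC(=O)Nc2nc3ccc(S(=O)(=O)CCCN4CCN(C)CC4)cc3s2)c1` gives 1500 nM, within the scatter of compound 1 `CCN(CC)CCCS(=O)(=O)c1ccc2nc(NC(=O)NC(=O)c3cc(-n4cccn4)ccc3Cl)sc2c1` at 1600 nM. Compound 3 `Cc1ccn(-c2ccc(Cl)c(C(=O)NC(=O)Nc3nc4ccc(S(=O)(=O)CCCN5CCN(C)CC5)cc4s3)c2)n1` carries 3-methyl-1H-pyrazol-1-yl in place of ethyl on an aromatic carbon of compound 2 (3-methyl-1H-pyrazol-1-yl in place of ethyl on an aromatic carbon). For the measured compounds named here, no measured pair isolates this change. Compound 1 also holds a five-membered aromatic ring of that kind, and its value of 1600 nM matches that of compound 2 within the scatter, though the two differ elsewhere too. No shift beyond the scatter is therefore expected in this assay. The expected step is a 1.1-fold lower number from compound 2 to compound 3 (0.03 log units; within the scatter), with no direction favoured. For compound 3 the estimated maximal plasma concentration is 1400 nM, with an expected range of 550 nM to 3500 nM.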

Compound 3, maximal plasma concentration: 410 nM
Compound 3: middle estimate off by 3.4-fold (0.53 log units), on the high side; measured number outside the range, below it.
By their numbers in this assay, from the lowest: compound 3; then compounds 2 and 1 (each within the scatter of the next).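

Placing 3-methyl-1H-pyrazol-1-yl in place of ethyl on the aromatic carbon para to a chloro group gives, in this assay, a 3.7-fold lower number from compound 2 to compound 3 (0.56 log units; beyond the scatter). For the compounds shown here, this is the first single-place step, and it shows that oral exposure responds to the group at this position. Nothing measured here accounts for the drop.

On these data alone, since the step replaces ethyl with a ring that also carries a methyl, the share of that methyl stays open. Also open, as far as these compounds go, is how a methoxy group or a nitrile would read at this position.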